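The source may hold more compounds than are shown below. What is called first, only, known or untested is meant among the compounds shown, and "the series" means these compounds.

Measured so far:
- compound 1, `CNC(=S)N/N=C/c1nccc2cc(F)ccc12`: 233 nM
- compound 2, `NC(=S)N/N=C/c1nccc2cc(F)ccc12`: 2040 nM
- compound 3, `CNC(=S)NN=Cc1nccc2c(NC)cccc12`: 607 nM

All three were tested in a functional assay on MIA PaCa-2 cells (Homo sapiens) for cytotoxicity, read by luminescence, with a stated time of 72 h, in the presence of a further agent that is not named here; a higher number here means a weaker inhibitor, a lower number a stronger inhibitor. Compound 1 and compound 2 share one core and differ in a single place: hydrogen in place of methyl on an amide-type nitrogen. That change made an 8.8-fold higher number from compound 1 to compound 2 (0.94 log units; beyond the scatter), so compound 2 sits at the weak end of the set. Compound 3 has a different core; the difference between the two cores is not broken down here. In this assay compound 3 gives 607 nM, between the other two.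

Compound 4, `CNC(=S)NN=Cc1nccc2c(N)cccc12`, has not yet been measured. It differs from compound 3 in one place: hydrogen in place of methyl on a nitrogen on an aromatic ring. For the measured compounds named here, this is the same kind of change as the one from compound 1 to compound 2, but not the same: there the methyl sat on an amide-type nitrogen whose other neighbours are a thiocarbonyl carbon, here it sits on a nitrogen on an aromatic ring whose other neighbours are an aromatic carbon. Going by the values given here, the only guide in this set is the step from compound 1 to compound 2. A weakening is expected for compound 4 too because of an 8.8-fold higher number from compound 1 to compound 2 (0.94 log units; beyond the scatter), though a smaller one is assumed: the place around the nitrogen is not the same. For compound 4 the expected step is a 2.0-fold higher number from compound 3 to compound 4 (0.30 log units; within the scatter), and the estimated value in this assay is 1200 nM, most likely between 400 nM and 4000 nM.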

Compound 4, half-maximal inhibitory concentration: 7080 nM
Compound 4: the middle estimate sits 5.9-fold (0.77 log units) below what was measured, and the stated range ends below it.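

In this assay, putting hydrogen in place of methyl on a nitrogen on an aromatic ring gives a 12-fold higher number from compound 3 to compound 4 (1.07 log units; beyond the scatter), a large loss of strength, and this loss is close in size to the one seen when the same swap was made on an amide-type nitrogen on the other core: the same change on two cores in this assay, an 8.8-fold higher number (0.94 log units; beyond the scatter) from compound 1 to compound 2 and a 12-fold higher number (1.07 log units; beyond the scatter) from compound 3 to compound 4, 1.3-fold (0.12 log units) apart, within the scatter of two such steps. Within these two pairs, then, removing a methyl from a nitrogen weakened the compound by a similar amount, even though the nitrogen sits in a different place and the core is different, so the earlier step was a fair guide to both the direction and the size of the new one. This does not show a general rule: two pairs cannot say whether the match would hold on other cores, and the data do not explain why either methyl matters or whether the two steps share a single cause.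

The compounds shown leave open whether a methyl is simply the best group on these nitrogens, or whether an ethyl group or a longer chain would keep or improve the strength. They also leave open how a dimethylamino group would compare with the methylamino group of compound 3.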